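A few compounds are considered here, and "the series" means these few. Any claim that something is new, unique, unknown or untested is made for them only; others in the source may bear on it.

Working notes on the series, read in a physicochemical assay for solubility, read by LC-MS, using the shake flask method, measured as thermodynamic solubility, with a stated time of 24 h, at pH 6.5; on this read-out lower numbers stand for lower solubility and higher numbers for higher solubility. Compound 1 `OC[C@H]1O[C@H](n2cc(-c3cccc(Cl)c3)nn2)[C@@H](O)[C@@H](O)[C@@H]1O` gives 705 ug/mL, and compound 2 `OC[C@H]1O[C@H](n2cc(-c3cccnc3)nn2)[C@@H](O)[C@@H](O)[C@@H]1O` gives 1380 ug/mL. Within the data shown here, these two numbers lie within the scatter of each other, so compound 2 stands level with the only other measured compound. The next compound is compound 3 `OC[C@H]1O[C@H](n2cc(COc3ccccc3)nn2)[C@@H](O)[C@@H](O)[C@@H]1O`, with phenoxymethyl in place of pyridin-3-yl on an aromatic carbon. Among the measured compounds shown here, only one measured step bears on this change, the exchange of 3-chlorophenyl for pyridin-3-yl at the same place, a 2.0-fold higher number from compound 1 to compound 2 (0.29 log units; within the scatter). For the measured compounds named here, it stayed within the scatter, but no measured compound carries phenoxymethyl, so it offers only indirect guidance. No step beyond the scatter is therefore expected in this assay, with a slight lean towards a lower number. The expected step is a 1.5-fold lower number from compound 2 to compound 3 (0.19 log units; within the scatter). For compound 3 the estimated value is 900 ug/mL, with an expected range of 350 ug/mL to 2000 ug/mL.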

Compound 3, solubility: > 3000 ug/mL
Compound 3: a limit, no number; the forecaster's own chance of this, stated with the estimate: 3%; at least 3.3-fold (0.52 log units) between middle value and limit.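

The reading for compound 3 in this assay, > 3000 ug/mL, is a limit of the assay and not a number: the limit of > 3000 ug/mL in this assay, at which 1 of the 3 values shown sits. Even so, this place on the five-membered aromatic ring now shows a change beyond the scatter, an at least 2.1-fold higher number from compound 2 to compound 3 (0.33 log units; beyond the scatter), whereas the exchange of 3-chlorophenyl for pyridin-3-yl stayed within it, a 2.0-fold higher number from compound 1 to compound 2 (0.29 log units; within the scatter). Phenoxymethyl also clears the scatter against 3-chlorophenyl, an at least 4.2-fold higher number from compound 1 to compound 3 (0.62 log units; beyond the scatter), so it stands apart from both groups in the earlier compounds.

On these data alone, how far compound 3 lies past its limit remains open, so both new steps give only a minimum size. Also open, as far as these compounds go, is whether the higher number goes with the oxygen of phenoxymethyl or with the rest of the group; a benzyl group, a methoxymethyl chain or an aminomethyl group at this place would help separate these.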